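Trifluoromethoxy in Place of Fluoro on Compound 1

This account rests on a few compounds, and the source may have more. Where it says the series, first, only, none or still open, it means among the compounds named here.

The measured compounds and their values:
- compound 1 `Oc1ccc(-c2cc(-c3cccc(F)c3)cc(-c3ccccc3O)n2)cc1`: in a functional assay on DU-145 cells (Homo sapiens) for inhibition (on this read-out higher numbers stand for weaker inhibition and lower numbers for stronger inhibition), compound 1 sits at the limit > 50000 nM
- compound 2 `Oc1ccc(-c2cc(-c3ccc(F)cc3)cc(-c3ccccc3O)n2)cc1`: in this assay compound 2 also sits at the limit > 50000 nM
- compound 3 `Oc1ccc(-c2cc(-c3cccc(F)c3)cc(-c3cccc(O)c3)n2)cc1`: in this assay compound 3 gives 2700 nM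

Compound 1 stands at a limit, not at a number, and so does compound 2; only compound 3 has a measured value. Two steps start from compound 1. The step that the two limits leave unreadable from compound 1 to compound 2 cannot be read, as both ends are limits (the limit of > 50000 nM in this assay, at which 2 of the 3 values shown sit). The step of an at least 18-fold lower number from compound 1 to compound 3 (1.26 log units; beyond the scatter) is large and points to the 2-hydroxyphenyl as what holds compound 1 at the limit.

Compound 4 `Oc1ccc(-c2cc(-c3cccc(OC(F)(F)F)c3)cc(-c3ccccc3O)n2)cc1` keeps that 2-hydroxyphenyl and differs from compound 1 only in trifluoromethoxy in place of fluoro on an aromatic carbon. For the measured compounds named here, no measured step bears on this fluoro position beyond the unreadable one from compound 1 to compound 2. Since the group that compound 3 shows to matter is unchanged, compound 4 is expected to remain at or near the limit, with an expected step that the limit leaves unreadable from compound 1 to compound 4. The estimate for compound 4 is 60000 nM, ranging from 15000 nM to 300000 nM.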

Compound 4, half-maximal inhibitory concentration: > 50000 nM
Compound 4: no number, only a limit; the forecaster's own chance of this, stated with the estimate: 70%; the middle value lies beyond the limit too.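

For the compounds shown here, compound 4 gives only a limit, > 50000 nM, in this assay, and compound 1 gives a limit too, so no step between compound 1 and compound 4 can be read: the limit of > 50000 nM in this assay, at which 3 of the 4 values shown sit. The compounds shown leave open what trifluoromethoxy in place of fluoro does to inhibition.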